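The source may hold more compounds than are shown below. What is called first, only, known or untested is meant among the compounds shown, and "the series" means these compounds.

Compound 1 `COc1cc(/C=C2\CC/C(=C\c3ccc([N+](=O)[O-])cc3)C2=O)cc(OC)c1OC`: in a functional assay on HPC cells (Homo sapiens) for cytotoxicity (on this read-out higher numbers stand for lower toxicity in this test and lower numbers for higher toxicity in this test), compound 1 gives > 400000 nM, which is a limit of the assay and not a number.
Compound 2 `COc1ccc(/C=C2\CCC/C(=C\c3ccc([N+](=O)[O-])cc3)C2=O)cc1OC`: in this assay compound 2 gives 82000 nM.
Compound 3 `COc1cc(/C=C2\CCC/C(=C\c3ccc([N+](=O)[O-])cc3)C2=O)cc(OC)c1OC`: in this assay compound 3 gives 347000 nM.

Among the three compounds, compound 2 stands at the lowest of the two actual numbers in this assay; the nearest measured neighbour is compound 3, reached by a 4.2-fold higher number from compound 2 to compound 3 (0.63 log units; beyond the scatter), a change that puts a methoxy in place of hydrogen on an aromatic carbon. For the measured compounds named here, the remaining value, that of compound 1, sits at the limit of > 400000 nM in this assay, at which 1 of the 3 values shown sits, so no step to it can be sized.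

Compound 4 `COc1ccc(/C=C2\CCC/C(=C\c3ccc([N+](=O)[O-])cc3)C2=O)cc1` is the one still to be measured. It differs from compound 2 by hydrogen in place of methoxy on an aromatic carbon, that is, a hydrogen in place of a methoxy on an aromatic carbon of the six-membered aromatic ring of carbon only, ortho to a methoxy group and meta to a large group. Going by the values given here, only one measured step bears on this change, and it runs the other way: adding a methoxy gave a 4.2-fold higher number from compound 2 to compound 3 (0.63 log units; beyond the scatter). Removing one is therefore expected to move the number in this assay downward, if at all, by a modest amount and possibly within the scatter.

On that basis compound 4 is estimated at 55000 nM, with a range from 20000 nM to 160000 nM. The step that this estimate means is expected to be a 1.5-fold lower number from compound 2 to compound 4 (0.17 log units; within the scatter), because the opposite change gave a 4.2-fold higher number from compound 2 to compound 3 (0.63 log units; beyond the scatter).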

Compound 4, half-maximal cytotoxic concentration: > 400000 nM
Compound 4: only a limit was reported (the forecaster's own chance of this, stated with the estimate: 5%); middle value at least 7.2-fold (0.86 log units) away from the limit.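

With hydrogen in place of the methoxy that sits ortho to a methoxy group and meta to a large group, this assay shows an at least 4.8-fold higher number from compound 2 to compound 4 (0.68 log units; beyond the scatter), so this methoxy clearly counts in this test. Set beside a 4.2-fold higher number from compound 2 to compound 3 (0.63 log units; beyond the scatter), this means that taking one methoxy away and adding another both raise the number, and among compounds 2, 3 and 4, which share one core, the lowest number belongs to compound 2 and the methoxy count does not order the three in a single direction. Compound 4 gives > 400000 nM, which is a limit of the assay and not a number, so its step has only a lower bound: the limit of > 400000 nM in this assay, at which 2 of the 4 values shown sit.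

On these data alone, how far above that limit compound 4 would lie stays open, and so does whether the same removal would have a comparable effect on the core of compound 1. Only methoxy and hydrogen are shown at this position, so it is also unknown whether a hydroxy group, an amine or a longer chain such as ethoxy there would keep the number of compound 2 or raise it as hydrogen does.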